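Piperazine nitrogen substituent in a CXCR4 agonist series

A few compounds are considered here, and "the series" means these few. Any claim that something is new, unique, unknown or untested is made for them only; others in the source may bear on it.

The shared core of compound 1 `CN(C[C@H]1Cc2c(cccc2N2CCN(Cc3ccccn3)CC2)CN1)[C@H]1CCCc2cccnc21` carries a substituted six-membered non-aromatic ring with two nitrogens, and two further members differ elsewhere: compound 2 `CCCN(C[C@H]1Cc2c(cccc2N2CCNCC2)CN1)[C@H]1CCCc2cccnc21` and compound 3 `Cc1cnc2c(c1)CCC[C@@H]2N(C)C[C@H]1Cc2c(cccc2N2CCNCC2)CN1`. In a functional assay on CCRF-CEM cells for agonist activity at C-X-C chemokine receptor type 4 (Homo sapiens), read by calcium flux, with a stated time of 25 min (on this read-out lower numbers stand for an effect already at smaller amounts and higher numbers for an effect only at larger amounts of compound), compound 1 gives only a limit of the assay, > 30000 nM. In this assay compound 2 likewise gives only a limit, > 30000 nM. Compound 3 also reaches only a limit in this assay, > 30000 nM. So far, then, every value in the set sits at the limit of > 30000 nM in this assay, at which 3 of the 3 values shown sit, and no measured step between two numbers is available, so compound 1 stands where all the others stand, at the limit rather than at a number.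

Compound 4 `CC(C)N1CCN(c2cccc3c2C[C@H](CN(C)[C@H]2CCCc4cccnc42)NC3)CC1` is the next candidate. It differs from compound 1 in one place: isopropyl in place of (pyridin-2-yl)methyl on an amine nitrogen in a ring. With all three known values at the same limit, no direction can be read off the series, and the step that the limit leaves unreadable from compound 1 to compound 4 is expected to be none beyond the usual scatter. Compound 4 is therefore estimated to give 35000 nM in this assay, with a range from 10000 nM to 120000 nM, most likely again reported only as a limit.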

Compound 4, half-maximal effective concentration: > 30000 nM
Compound 4: a limit, no number; the forecaster's own chance of this, stated with the estimate: 80%; the middle value does not contradict the limit.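

In this assay compound 4 gives only the limit > 30000 nM and no number. Among these compounds, compound 1 also stands at a limit, so no step between compound 1 and compound 4 can be read. The compounds shown leave open whether any change to the shared core gives a number rather than a limit in this assay at all.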